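The compounds below may be only part of what the source reports. "The series", "measured", "known", "first", "only" and "open" are said of these compounds alone.

Measured so far in a functional assay on Rec1 cells (Homo sapiens) for inhibition, read by luminescence and CellTiter-Glo, with a stated time of 72 h; a higher number here means a weaker inhibitor, a lower number a stronger inhibitor:

Compound 1 `O=C(CCl)N1CCCC(n2nc(-c3ccc(Oc4ccccc4)cc3)cc2CO)C1` gives 400 nM.
Compound 2 `C=CC(=O)N1CCCC(n2nc(-c3ccc(Oc4ccccc4)cc3)cc2CO)C1` gives 5400 nM.
Compound 3 `O=C(CCl)Nc1cccc(Cn2nc(-c3ccc(Oc4ccccc4)cc3)cc2C(=O)O)c1` gives 7100 nM.

Compound 1 stands lowest of the three and is therefore the strongest inhibitor among them. Its nearest neighbour is compound 2: the step of a 14-fold higher number from compound 1 to compound 2 (1.13 log units; beyond the scatter) comes from swapping vinyl in place of chloromethyl on a carbonyl carbon. Compound 3 lies furthest away, and it differs from compound 1 in several places at once, so its two values only show that the other arrangement is much weaker.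

Compound 4 `CCOC(=O)c1cc(-c2ccc(Oc3ccccc3)cc2)nn1C1CCCN(C(=O)CCl)C1` keeps the piperidine, the chloromethyl carbonyl and the rest of the core of compound 1, and differs in one place: ethoxycarbonyl in place of hydroxymethyl on an aromatic carbon. Among the measured compounds shown here, none of the measured steps touches this position; the single known step concerns the carbonyl carbon instead. The expectation therefore rests on the change itself rather than on a matching precedent, and a moderate shift towards a higher number seems most likely, with the direction far from certain.

Compound 4 is estimated at 1500 nM, within a range of 300 nM to 7000 nM, which means an expected step of a 3.8-fold higher number from compound 1 to compound 4 (0.57 log units; beyond the scatter).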

Compound 4, half-maximal inhibitory concentration: 400 nM
Estimate against measurement, compound 4: 3.8-fold (0.57 log units) above; the measured number falls inside the stated range.
By their numbers in this assay, from the lowest: compounds 1 and 4 (each within the scatter of the next); then compounds 2 and 3 (each within the scatter of the next).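

Ethoxycarbonyl in place of hydroxymethyl on this aromatic carbon, next to the ring nitrogen, gives no change at the digits printed from compound 1 to compound 4 (within the scatter) in this assay. This position on the core of compound 1 therefore accepts the larger ethoxycarbonyl without the hydrogen-bond donor of hydroxymethyl, whereas the change on the carbonyl carbon gives a 14-fold higher number from compound 1 to compound 2 (1.13 log units; beyond the scatter). Nothing measured here accounts for why the two groups read alike.

Going by these compounds, it remains open whether an amine, an amide or a longer chain on this aromatic carbon would also leave the number in place. On these data alone, it is equally open whether ethoxycarbonyl would behave the same way alongside the vinyl carbonyl of compound 2.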